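Fluoro for hydroxy on a quinoline core against P388 cells

The compounds below may be only part of what the source reports. "The series", "measured", "known", "first", "only" and "open" are said of these compounds alone.

Measured so far:
compound 1, `Oc1cc(-c2ccccc2)nc2c(O)cccc12`: > 10 ug/mL
compound 2, `CC(C)COc1cc(-c2ccccc2)nc2ccccc12`: > 10 ug/mL

In a functional assay on P388 cells (Mus musculus) for cytotoxicity (on this read-out higher numbers stand for an effect only at larger amounts of compound and lower numbers for an effect already at smaller amounts), compound 1 reaches only a limit, > 10 ug/mL, and not a number. Compound 2 likewise reaches only a limit, > 10 ug/mL. Compound 1 therefore stands at the edge of what this assay reports, a position described by the limit of > 10 ug/mL in this assay, at which 2 of the 2 values shown sit.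

The unmeasured compound 3, `Oc1cc(-c2ccccc2)nc2c(F)cccc12`, differs from compound 1 by fluoro in place of hydroxy on an aromatic carbon. Within the data shown here, no step between two measured compounds is available that would show how such a change moves this read-out. With both measured values sitting at the limit, the only expectation that rests on the data is a step no larger than the scatter in this assay. The expected step that the limit leaves unreadable from compound 1 to compound 3 is estimated to be none beyond the scatter. Compound 3 is expected to give 15 ug/mL, with a range from 5 ug/mL to 50 ug/mL.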

Compound 3, half-maximal effective concentration: 0.67 ug/mL
The estimate for compound 3 lay 22-fold (1.35 log units) above the measured number, and the stated range ends above it.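

In this assay, fluoro in place of hydroxy on an aromatic carbon gives an at least 14-fold lower number from compound 1 to compound 3 (1.17 log units; beyond the scatter), and compound 3 is the first compound shown to yield a number rather than a limit. Among these compounds, the change shows that this carbon, ortho to a fused ring and meta to a fused ring, is not indifferent to what it carries, something the earlier compounds could not show. The step can be stated only as a bound because its starting point is a limit: the limit of > 10 ug/mL in this assay, at which 2 of the 3 values shown sit.

The compounds shown leave open whether the lower number follows from fluoro itself or simply from the loss of hydroxy, a question that plain hydrogen, chloro, methoxy or an amine on the same carbon would address. Also open, on these data alone, is what part the remaining hydroxy, shared by compound 1 and compound 3, plays in this read-out.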